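Bromo in place of ethyl on compound 3

The source may report more compounds than this note shows. Statements on the series, on what has been measured and on what is new or still open speak of the compounds shown alone.

In a functional assay on MGC-803 cells (Homo sapiens) for inhibition, read by MTT assay, with a stated time of 48 h (on this read-out higher numbers stand for weaker inhibition and lower numbers for stronger inhibition), compound 3 (`CCC/C=C/C(=O)N(Cc1ccc(OC)c(O)c1)c1cc(OC)c(OC)c(OC)c1`) gives 70 nM. Compound 1 (`COc1ccc(CN(C(=O)C(C)Br)c2cc(OC)c(OC)c(OC)c2)cc1O`) gives 120 nM, within the scatter of compound 3, so the two stand level at the low end of the three numbers. Compound 2 (`COc1ccc(CNc2cc(OC)c(OC)c(OC)c2)cc1Br`) gives a far higher number, 29400 nM.

Compound 4 (`COc1ccc(CN(C(=O)/C=C/CBr)c2cc(OC)c(OC)c(OC)c2)cc1O`) departs from compound 3 by bromo in place of ethyl on a saturated chain carbon bound to a double-bonded chain carbon. Cut one bond further out, this reads pent-1-en-1-yl to 3-bromoprop-1-en-1-yl. Going by the values given here, the one measured step on this chain, a 1.7-fold lower number from compound 1 to compound 3 (0.23 log units; within the scatter), put pent-1-en-1-yl in place of 1-bromoethyl on a carbonyl carbon and stayed within the scatter. No measurement isolates the exact exchange at hand, so the evidence is indirect. No change beyond the scatter is therefore expected in this assay, and the estimated step is a 1.1-fold higher number from compound 3 to compound 4 (0.06 log units; within the scatter). The expected value for compound 4 is 80 nM, with an estimated range from 25 nM to 250 nM.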

Compound 4, half-maximal inhibitory concentration: 71 nM
Compound 4: middle estimate off by 1.1-fold (0.05 log units), on the high side; the range from low to high includes it.
By their numbers in this assay, from the lowest: compounds 3, 4 and 1 (each within the scatter of the next); then compound 2.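

In this assay the exchange of ethyl for bromo on a saturated chain carbon bound to a double-bonded chain carbon gave a 1.0-fold higher number from compound 3 to compound 4 (0.01 log units; within the scatter), so at this position the two groups cannot be told apart. Placing 3-bromoprop-1-en-1-yl instead of 1-bromoethyl on a carbonyl carbon gave a 1.7-fold lower number from compound 1 to compound 4 (0.23 log units; within the scatter), so compound 4 also stands level with compound 1, and bromine can be carried on either chain without a step beyond the scatter. No available measurement explains why these changes leave the number in place.

As far as these compounds go, whether this position would accept a very different group, such as an amine or a carboxylic acid, remains open. From the compounds shown here alone, it is also open whether a longer chain ending in bromomethyl would stay level with compound 4.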